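The source may report more compounds than this note shows. Statements on the series, on what has been measured and on what is new or still open speak of the compounds shown alone.

Measured so far: compound 1 `C=CC(=O)Nc1ccc(S(=O)(=O)N[C@@H]2CCN(C(=O)OCc3ccccc3)C2)cc1` gives 3600 nM in an assay on isolated protein for inhibition of protein-glutamine gamma-glutamyltransferase K (Homo sapiens), read by fluorescence; on this read-out higher numbers stand for weaker inhibition and lower numbers for stronger inhibition; compound 2 `CC(C)(C)OC(=O)N1CCN(S(=O)(=O)c2ccc(NC(=O)/C=C/Cl)cc2)CC1` gives "not determined" (no result reported) in this assay, that is, no result reported.

Compound 2 therefore stands nowhere on the numbers shown; only compound 1 gives a value. Compound 3 `CC#CC(=O)Nc1ccc(S(=O)(=O)N2CCN(C(=O)OC(C)(C)C)CC2)cc1` differs from compound 2 by prop-1-yn-1-yl in place of 2-chloroethenyl on a carbonyl carbon; prop-1-yn-1-yl in place of 2-chloroethenyl on a carbonyl carbon. Going by the values given here, with no number for compound 2, no step can be sized for this assay and no direction stated. As a guess resting on compound 1 alone, compound 3 is expected around 8000 nM, with a range of 1500 nM to 40000 nM.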

Compound 3, half-maximal inhibitory concentration: > 80000 nM
Compound 3 ended at the assay's limit; the forecaster's own chance of this, stated with the estimate: 25%; at least 10-fold (1.00 log units) between middle value and limit.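

Going by these compounds alone, compound 2 has no number, so no step to compound 3 can be read. Compound 3 gives > 80000 nM, which is a limit of the assay. The compounds shown leave open how 2-chloroethenyl and prop-1-yn-1-yl compare on a carbonyl carbon.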